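The source may report more compounds than this note shows. Statements on the series, on what has been measured and on what is new or still open speak of the compounds shown alone.

Measured so far:
compound 1 `Cc1nc(N)sc1CCCN/C(N)=N/C(=O)NC(C)c1cccc(F)c1` gives 0.3
compound 2 `CCCCCNC(=O)/N=C(\N)NCCCc1sc(N)nc1C` gives 0.15
compound 3 `CCCCCCNC(=O)/N=C(\N)NC1CCc2nc(N)sc2C1` gives "not determined" (no result reported)

In a functional assay on HEK293T cells for agonist activity at histamine H2 receptor (Homo sapiens), read by beta-arrestin recruitment (on this read-out lower numbers stand for smaller maximal responses and higher numbers for larger maximal responses), compound 2 gives 0.15, the lowest of the two numbers recorded. Its nearest neighbour on this read-out is compound 1, which gives 0.3, and that gap lies beyond the scatter of repeated measurements. Compound 3 belongs to the same series but no number is recorded for it in this assay.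

Compound 4 `CCCNC(=O)/N=C(\N)NCCCc1sc(N)nc1C` has not yet been measured. It differs from compound 2 in one place: hydrogen in place of ethyl on a saturated chain carbon, three bonds along the chain from an amide-type nitrogen. Among the compounds with values here, no step between measured compounds touches this part of the structure, so the data give no direct guide to how the chain length at this position affects the maximal response. Compound 1, which gives 0.3, and compound 2, which gives 0.15, differ in a quite separate part of the molecule, and their gap says nothing about the chain.

Given the absence of a comparable step, the expectation for compound 4 is a change from compound 2 of no change at the digits printed from compound 2 to compound 4 (within the scatter), that is, none beyond the scatter. Compound 4 is therefore estimated at 0.15, with a range from 0.05 to 0.3.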

Compound 4, intrinsic activity: the largest response reached, as a fraction of the reference agonist's: 0.32
The estimate for compound 4 lay 0.17 below the measured number; the whole stated range lies below it.
By their numbers in this assay, from the lowest: compound 2; then compounds 1 and 4 (each within the scatter of the next).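

This is the first step shown that touches the chain: in this assay, pentyl shortened to propyl, with hydrogen in place of ethyl on a saturated chain carbon, three bonds along the chain from an amide-type nitrogen, gives a number 0.17 higher from compound 2 to compound 4 (beyond the scatter). The maximal response is therefore sensitive to this position, and of this pair, the shorter chain gives the larger response. Nothing among the available data accounts for the step.

With only these two chain lengths on this core, a single step cannot establish a trend with chain length. As far as these compounds go, what a butyl chain would give at this position remains open, as does the effect of an amine or a carboxylic acid on the same saturated chain carbon.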